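The compounds below may be only part of what the source reports. "The series", "measured", "known", "first", "only" and "open" are said of these compounds alone.

Measured compounds in a functional assay on L1210 cells (Mus musculus) for inhibition; a higher number here means a weaker inhibitor, a lower number a stronger inhibitor:

- Compound 1 `C=C1[C@@H](O)[C@H](n2cnc3c(O)nc(N)nc32)O[C@@H]1CO`. In this assay compound 1 gives > 200000 nM.
- Compound 2 `C=C1[C@@H](O)[C@H](n2cnc3c(O)ncnc32)O[C@@H]1CO`. In this assay compound 2 gives > 200000 nM.
- Compound 3 `C=C1[C@H](n2cnc3c(N)nc(N)nc32)O[C@H](CO)[C@H]1O`. In this assay compound 3 gives 8200 nM.

For compound 1 the value > 200000 nM in this assay is a limit of the assay, not a number. For compound 2 the value > 200000 nM is likewise a limit. The change between them is hydrogen in place of amino on an aromatic carbon, and the step it made, a step that the two limits leave unreadable from compound 1 to compound 2, cannot be read as a size, with both values sitting at the limit of > 200000 nM in this assay, at which 2 of the 3 values shown sit. Among the compounds with values here, compound 3 gives 8200 nM, the only number in the set. How the core of compound 3 differs from the core of compound 1 is not broken down here.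

Compound 4 `C=C1[C@H](n2cnc3c(N)ncnc32)O[C@H](CO)[C@H]1O` is not yet measured. It differs from compound 3 by hydrogen in place of amino on an aromatic carbon. Within the data shown here, the place is not word for word the one in compound 1 and compound 2: there the carbon is meta to a hydroxy group, here it is meta to an amino group. It is the same kind of change, not the same.

Among the measured compounds shown here, the expected step from compound 3 to compound 4 is a 2.4-fold higher number from compound 3 to compound 4 (0.39 log units; beyond the scatter), a guess that rests on little, since the only precedent a step that the two limits leave unreadable from compound 1 to compound 2 has no readable size and the two cores differ in an uncounted way. Compound 4 is therefore estimated at 20000 nM in this assay, with a wide range from 3000 nM to 150000 nM.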

Compound 4, half-maximal inhibitory concentration: 65000 nM
Compound 4: middle estimate off by 3.3-fold (0.51 log units), on the low side, and the stated range covers the measured number.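

In this assay, hydrogen in place of amino on an aromatic carbon, at the place between two ring nitrogen atoms, gives a 7.9-fold higher number from compound 3 to compound 4 (0.90 log units; beyond the scatter), which is the only readable size for this change in the series. The same kind of change in the core of compound 1 cannot be read because compound 1 and compound 2 both stand at a limit of the assay, not at a number: the limit of > 200000 nM in this assay, at which 2 of the 4 values shown sit. The pair compound 3 and compound 4 therefore shows what the change does in one core only; it does not show that the step carries over to the core of compound 1, where the place is also not word for word the same, and a single readable pair makes no trend.

Still open is whether the amino group at this place can be replaced by anything that keeps the number of compound 3, for example a methyl group, a chlorine atom or a methylamino group, since the compounds shown carry only amino or hydrogen there. Also open, on these data alone, is whether any such group would bring the core of compound 1 to a readable number in this assay, which a comparison between the two cores would need.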